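From fluoro to bromo on the aromatic carbon

The compounds below may be only part of what the source reports. "The series", "measured", "known", "first", "only" and "open" are said of these compounds alone.

In an ADME assay on HeLa cells (Homo sapiens) for cytotoxicity, read by MTT assay, with a stated time of 72 h (a higher number here means a weaker inhibitor of growth, a lower number a stronger inhibitor of growth), compound 1 `O=C(/C=C\c1cccc([N+](=O)[O-])c1)N1N=C(c2ccncc2)OC1c1c[nH]c2ccccc12` gives > 30 ug/mL as a limit of the assay. Compound 2 `Cc1ccc(/C=C\C(=O)N2N=C(c3ccncc3)OC2c2c[nH]c3ccccc23)cc1` gives > 30 ug/mL as a limit too. Compound 3 `O=C(/C=C\c1cccc(F)c1)N1N=C(c2ccncc2)OC1c1c[nH]c2ccccc12` likewise gives > 30 ug/mL as a limit and no number. Among the measured compounds shown here, the series so far rests on the limit of > 30 ug/mL in this assay, at which 3 of the 3 values shown sit, and nothing firmer. Compound 4 `O=C(/C=C\c1cccc(Br)c1)N1N=C(c2ccncc2)OC1c1c[nH]c2ccccc12` has bromo in place of fluoro on an aromatic carbon, meta to a large group bromo in place of fluoro on an aromatic carbon in the counted change. The nearest evidence is a step that the two limits leave unreadable from compound 1 to compound 3 and a step that the two limits leave unreadable from compound 2 to compound 3 with no size to carry over, and a step that the two limits leave unreadable from compound 1 to compound 2 adds none. No step beyond the scatter is expected, and no direction, so the estimate is a step that the limit leaves unreadable from compound 3 to compound 4 at most loosely. Compound 4 is expected at 40 ug/mL with 20 ug/mL to 80 ug/mL as its estimated range.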

Compound 4, concentration for 50% growth inhibition: > 30 ug/mL
Compound 4: only a limit was reported; the forecaster's own chance of this, stated with the estimate: 80%; the middle value does not contradict the limit.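

Compound 4 gives > 30 ug/mL in this assay, which is a limit and not a number. Among the compounds shown here, no step among compounds 1, 2, 3 and 4 can therefore be read. The compounds shown leave open whether these groups differ at all in growth inhibition, and by how much: the limit of > 30 ug/mL in this assay, at which 4 of the 4 values shown sit.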